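The source may report more compounds than this note shows. Statements on the series, on what has been measured and on what is new or still open speak of the compounds shown alone.

Of the compounds shown here, three built on one shared core have been tested in a functional assay on BXPC-3 cells (Homo sapiens) for antiproliferative activity, read by MTT assay, with a stated time of 24 h; a higher number here means a weaker inhibitor, a lower number a stronger inhibitor. Compound 1 `CCn1c(C(=O)N[C@H](C)C(=O)OC)ccc1C(CC)(CC)c1ccc(OCS(=O)(=O)c2ccccc2)c(C)c1` carries a 1-(methoxycarbonyl)ethyl group on an amide-type nitrogen. In this assay compound 1 reaches only the limit of the measurement, > 50000 nM. Compound 2 `CCn1c(C(=O)NCCC(=O)OC)ccc1C(CC)(CC)c1ccc(OCS(=O)(=O)c2ccccc2)c(C)c1` carries 2-(methoxycarbonyl)ethyl in the same place. In this assay compound 2 likewise sits at the limit, > 50000 nM. Within the data shown here, compound 3 `CCn1c(C(=O)NC(C)(C)CO)ccc1C(CC)(CC)c1ccc(OCS(=O)(=O)c2ccccc2)c(C)c1` carries 1-(hydroxymethyl)-1-methylethyl on that nitrogen, and in this assay compound 3 gives 18300 nM, the one readable number of the three. The step that the two limits leave unreadable from compound 1 to compound 2 cannot be sized. The steps of an at least 2.7-fold lower number from compound 1 to compound 3 (0.43 log units; beyond the scatter) and an at least 2.7-fold lower number from compound 2 to compound 3 (0.43 log units; beyond the scatter) show that a change on the amide-type nitrogen can bring the number into the readable range. Compound 4 `CCn1c(C(=O)NCCC(=O)O)ccc1C(CC)(CC)c1ccc(OCS(=O)(=O)c2ccccc2)c(C)c1` has not yet been measured; it differs from compound 2 by hydrogen in place of methyl on an oxygen next to a carbonyl group. Among the measured compounds shown here, none of the measured steps turns a methyl ester into the free acid, so no measured step sizes this change directly; the only guide is the limit of > 50000 nM in this assay, at which 2 of the 3 values shown sit. Compound 4 is expected to stay near that limit, at an estimated 50000 nM with a range from 20000 nM to 150000 nM. The expected step is a number no higher from compound 2 to compound 4 (the limit leaves the size open).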

Compound 4, half-maximal inhibitory concentration: > 50000 nM
Compound 4: only a limit was reported; the forecaster's own chance of this, stated with the estimate: 70%; the middle value lies on the limit itself.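

In this assay compound 4 gives > 50000 nM, which is a limit of the assay and not a number. Replacing the methyl of the ester with hydrogen therefore does not bring this chain into the readable range, and the steps from compound 2 and from compound 1 to compound 4 cannot be read, as both ends of each are limits. The one readable step is an at least 2.7-fold higher number from compound 3 to compound 4 (0.43 log units; beyond the scatter), so among the four compounds only the 1-(hydroxymethyl)-1-methylethyl group on the amide-type nitrogen gives a readable number, while the two methyl esters and the free acid all rest at the limit: the limit of > 50000 nM in this assay, at which 3 of the 4 values shown sit.

On these data alone, how far compound 2 and compound 4 lie past that limit stays unknown, so no order between the methyl ester and the free acid can be given. As far as these compounds go, it also remains open what an amine or a longer chain ending in hydroxy would do on the same nitrogen, and whether the hydroxy group or the two methyl groups of compound 3 matter more for its readable value.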